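Swapping the aryl group on a dihydropyridine core

The source may report more compounds than this note shows. Statements on the series, on what has been measured and on what is new or still open speak of the compounds shown alone.

Measured compounds:
compound 1 `COC(=O)C1=C(C)N=C(C)/C(=C(\O)OC)C1c1ccc(Cl)cc1`: 8130 nM
compound 2 `COC(=O)C1=C(C)N=C(C)/C(=C(\O)OC)C1c1ccccc1N`: 39800 nM
compound 3 `COC(=O)C1=C(C)N=C(C)/C(=C(\O)OC)C1c1ccccc1C#N`: 15.9 nM

In a functional assay (muscle tissue) with Cavia porcellus as the target (on this read-out higher numbers stand for an effect only at larger amounts of compound and lower numbers for an effect already at smaller amounts), compound 1 stands second highest of the three numbers; the nearest is compound 2, and the step of a 4.9-fold higher number from compound 1 to compound 2 (0.69 log units; beyond the scatter) lies beyond the scatter, while the step of a 510-fold lower number from compound 1 to compound 3 (2.71 log units; beyond the scatter) is large. Compound 4 `COC(=O)C1=C(C)N=C(C)/C(=C(\O)OC)C1c1cc(C)ccc1C` is not yet measured. It differs from compound 1 in one place: 2,5-dimethylphenyl in place of 4-chlorophenyl on a saturated ring carbon. Both measured steps from compound 1 also exchange the 4-chlorophenyl for a phenyl bearing a substituent on an aromatic carbon, yet they point in opposite directions, so the direction for a 2,5-dimethylphenyl is uncertain. A modest step downward is expected, a 2.7-fold lower number from compound 1 to compound 4 (0.43 log units; beyond the scatter), giving an estimated value for compound 4 of 3000 nM with a range from 300 nM to 30000 nM.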

Compound 4, half-maximal effective concentration: 100 nM
Beside the measured number, compound 4's estimate is 30-fold (1.48 log units) above it, outside the stated range (below it).
By their numbers in this assay, from the lowest: compound 3; then compound 4; then compound 1; then compound 2.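

In this assay, the 2,5-dimethylphenyl brings an 81-fold lower number from compound 1 to compound 4 (1.91 log units; beyond the scatter) and a 400-fold lower number from compound 2 to compound 4 (2.60 log units; beyond the scatter), so a low number at this position does not depend on the nitrile of compound 3. Even so, the nitrile compound keeps the lowest number of the four, with a 6.3-fold higher number from compound 3 to compound 4 (0.80 log units; beyond the scatter). No measurement here accounts for these steps. From the compounds shown here alone, it remains open whether a single methyl group would do as much as the pair in the 2,5-dimethylphenyl, and how a methoxy group or a fluorine on that phenyl ring would compare.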